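The source may hold more compounds than are shown below. What is called first, only, known or untested is meant among the compounds shown, and "the series" means these compounds.

Compound 1 `COc1ccccc1/C=c1/[nH]c(=O)/c(=C\c2ccccc2OC)n(C)c1=O`: 7000 nM
Compound 2 `C=CCn1c(=O)/c(=C\c2ccccc2Cl)[nH]c(=O)/c1=C\c1ccccc1OC`: 5300 nM
Compound 3 `COc1ccccc1/C=c1\c(=O)[nH]/c(=C/c2cccc(Cl)c2Cl)c(=O)n1C`: 200 nM

These numbers come from a functional assay on A549 cells (Homo sapiens) for cytotoxicity, read by CCK-8 assay, with a stated time of 72 h; a higher number here means a weaker inhibitor, a lower number a stronger inhibitor. Compound 3 has the lowest number of the three at 200 nM, and both others lie well beyond the usual scatter from it. Compound 4 `COc1ccccc1/C=c1\c(=O)[nH]/c(=C/c2ccccc2Cl)c(=O)n1C` differs from compound 3 in one place: hydrogen in place of chloro on an aromatic carbon. In words, hydrogen replaces chloro on an aromatic carbon, turning 2,3-dichlorophenyl into 2-chlorophenyl.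

Within the data shown here, the only measured step touching this group is large, a 35-fold lower number from compound 1 to compound 3 (1.54 log units; beyond the scatter), but it replaced 2-methoxyphenyl, so it bears on the change only indirectly. The closest relative with a 2-chlorophenyl group is compound 2 at 5300 nM, yet it also has an allyl group where compound 3 has methyl. Its number may therefore overstate what losing the chloro does.

A clear rise in this assay is expected, an estimated 7.5-fold higher number from compound 3 to compound 4 (0.88 log units; beyond the scatter), though smaller than the measured step. For compound 4 the estimated value is 1500 nM, with an expected range of 400 nM to 6000 nM.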

Compound 4, half-maximal inhibitory concentration: 300 nM
Compound 4: the middle estimate sits 5.0-fold (0.70 log units) above what was measured; measured number below the stated range.
By their numbers in this assay, from the lowest: compounds 3 and 4 (each within the scatter of the next); then compounds 2 and 1 (each within the scatter of the next).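

In this assay, the chloro lost here turns out to matter little: going from 2,3-dichlorophenyl to 2-chlorophenyl leaves the two compounds indistinguishable (a 1.5-fold higher number from compound 3 to compound 4 (0.18 log units; within the scatter)). The large gain over the methoxy compound therefore does not need both chloro groups, since a single chloro in place of methoxy already gives it (a 23-fold lower number from compound 1 to compound 4 (1.37 log units; beyond the scatter)). The poor number of compound 2 now points to its allyl group rather than to the missing chloro, as methyl in place of allyl on the aromatic nitrogen gives a large step (an 18-fold lower number from compound 2 to compound 4 (1.25 log units; beyond the scatter)).

No measurement shown explains why these changes act as they do. On these data alone, whether a fluoro or a nitrile could stand in place of the remaining chloro, or an ethyl in place of the methyl, stays open.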